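Ring size at the sulfonamide nitrogen in cytotoxic oxa-bridged acids

This account rests on a few compounds, and the source may have more. Where it says the series, first, only, none or still open, it means among the compounds named here.

Of the compounds shown here, three sharing one core have been tested. Compound 1 `CCN1CCN(S(=O)(=O)c2ccc(NC(=O)C3C(C(=O)O)[C@H]4CC[C@@H]3O4)cc2)CC1` gives 15700 nM in a functional assay on HeLa cells (Homo sapiens) for cytotoxicity, read by MTT assay, with a stated time of 48 h; a lower number here means a stronger inhibitor, a higher number a weaker inhibitor. Compound 2 `O=C(Nc1ccc(S(=O)(=O)N2CCOCC2)cc1)C1C(C(=O)O)[C@H]2CC[C@@H]1O2` gives 17200 nM. Compound 3 `O=C(Nc1ccc(S(=O)(=O)NC2CCCC2)cc1)C1C(C(=O)O)[C@H]2CC[C@@H]1O2` gives 17600 nM. The three differ only in the group on the sulfonyl sulfur, and the steps among them are small: a 1.1-fold higher number from compound 1 to compound 2 (0.04 log units; within the scatter), a 1.1-fold higher number from compound 1 to compound 3 (0.05 log units; within the scatter) and a 1.0-fold higher number from compound 2 to compound 3 (0.01 log units; within the scatter). Compound 3 therefore cannot be told apart from compound 1 or compound 2 on these numbers; all three sit together within the scatter.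

Compound 4 `O=C(Nc1ccc(S(=O)(=O)NC2CC2)cc1)C1C(C(=O)O)[C@H]2CC[C@@H]1O2` is the next step from compound 3: cyclopropyl in place of cyclopentyl on a sulfonamide nitrogen. The earlier steps shown here all swapped the whole group on the sulfonyl sulfur, and none moved the number beyond the scatter. The present change is smaller still, a carbocyclic ring of one size for another on the same nitrogen. Within the data shown here, no measured step speaks for a shift in either direction, so for compound 4 a step of a 1.0-fold higher number from compound 3 to compound 4 (0.01 log units; within the scatter) is expected, essentially none beyond the scatter. The estimate for compound 4 is 18000 nM, with a range from 9000 nM to 36000 nM.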

Compound 4, half-maximal inhibitory concentration: 20900 nM
Compound 4: the middle estimate sits 1.2-fold (0.06 log units) below what was measured, within the range that was stated.
By their numbers in this assay, from the lowest: compounds 1, 2, 3 and 4 (each within the scatter of the next).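

Swapping cyclopentyl for cyclopropyl on the sulfonamide nitrogen gives a 1.2-fold higher number from compound 3 to compound 4 (0.07 log units; within the scatter) in this assay, so this difference in carbocyclic ring size leaves the number within the scatter. Compound 4 also stays within the scatter of the compounds with other groups on the sulfonyl sulfur, with a 1.2-fold higher number from compound 2 to compound 4 (0.08 log units; within the scatter) and with a 1.3-fold higher number from compound 1 to compound 4 (0.12 log units; within the scatter) as well, so none of the four groups shown separates itself from the others, and no compound goes against this. Nothing measured here bears on why the numbers stay so close.

Going by these compounds, whether a phenyl ring or a chain ending in a carboxylic acid on this nitrogen would move the number remains open. On these data alone, all four compounds also keep the same core with its carboxylic acid, so the effect of a methyl ester in its place is unknown.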